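Chromene chalcone series: nitro replacing imidazolyl on aryl ring

The source may hold more compounds than are shown below. What is called first, only, known or untested is meant among the compounds shown, and "the series" means these compounds.

Compound 1 `COc1ccc(C(=O)/C=C/c2cccc(F)c2)c2c1C=CC(C)(C)O2`: > 10000 nM in a functional assay on HepG2 cells (Homo sapiens) for antiproliferative activity, read by MTT assay, with a stated time of 24 h; on this read-out higher numbers stand for weaker inhibition and lower numbers for stronger inhibition
Compound 2 `CCN(CC)c1ccc(/C=C/C(=O)c2ccc(OC)c3c2OC(C)(C)C=C3)cc1`: 590 nM
Compound 3 `COc1ccc(C(=O)/C=C/c2ccc(-n3ccnc3)cc2)c2c1C=CC(C)(C)O2`: > 10000 nM
Compound 4 `COc1ccc(C(=O)/C=C/c2ccc([N+](=O)[O-])cc2)c2c1C=CC(C)(C)O2`: not yet measured

Compound 3 sits at the limit of this assay, and its value is a limit rather than a number. Compound 1 likewise reports a limit. For the measured compounds named here, only compound 2, with diethylamino on the aromatic carbon, gives a number, and the single measured step, an at least 16-fold higher number from compound 2 to compound 3 (1.22 log units; beyond the scatter), is large and beyond the scatter.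

The change to compound 4 is nitro in place of 1H-imidazol-1-yl on an aromatic carbon. Going by the values given here, no measured step covers a nitro group, so the only guide is that compound 3 already stands at the limit and that the limit of > 10000 nM in this assay, at which 2 of the 3 values shown sit, marks where most of the series sits. Nothing in the numbers shown gives reason to expect the nitro analogue to fall to the level of compound 2.

Compound 4 is therefore expected to remain at or near the limit, estimated at 10000 nM with a range of 3000 nM to 30000 nM. The expected step is a number no higher from compound 3 to compound 4 (the limit leaves the size open), which is not expected to exceed the scatter.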

Compound 4, half-maximal inhibitory concentration: 2610 nM
Compound 4: middle estimate off by 3.8-fold (0.58 log units), on the high side; the measured number lies below the stated range.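

On the aromatic carbon para to a large group in this assay, a measurable number does not depend on diethylamino: the change to nitro gives an at least 3.8-fold lower number from compound 3 to compound 4 (0.58 log units; beyond the scatter), so the loss seen with 1H-imidazol-1-yl does not extend to every replacement of diethylamino. Nitro still does not match diethylamino, with a 4.4-fold higher number from compound 2 to compound 4 (0.65 log units; beyond the scatter). The 4-nitrophenyl group also separates from 3-fluorophenyl, with an at least 3.8-fold lower number from compound 1 to compound 4 (0.58 log units; beyond the scatter), yet limits still mark much of the series: the limit of > 10000 nM in this assay, at which 2 of the 4 values shown sit.

From the compounds shown here alone, whether a primary amine, dimethylamino or a carboxylic acid on this carbon would fall closer to diethylamino or to nitro remains open. Going by these compounds, the steps from compound 1 and compound 3 both rest on limits, so their full size also remains open.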